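Working notes on solubility: the step to compound 4

The compounds below may be only part of what the source reports. "The series", "measured", "known", "first", "only" and "open" are said of these compounds alone.

Measured compounds in a physicochemical assay for solubility, in phosphate buffer, at pH 6.8; a lower number here means a less soluble compound, a higher number a more soluble compound:
compound 1 `CCn1c(NC2CCOCC2)nc2ccsc2c1=O`: 37 ug/mL
compound 2 `CCn1c(NC(C)C)nc2c(-c3cccnc3)csc2c1=O`: 5.8 ug/mL
compound 3 `CCn1c(NC2CC2)nc2ccsc2c1=O`: 430 ug/mL

Compound 2 stands lowest of the three numbers in this assay; compound 1 sits nearest above it and compound 3 furthest above it. Going by the values given here, the one single-point step measured so far, a 12-fold higher number from compound 1 to compound 3 (1.07 log units; beyond the scatter), concerns the group on the ring nitrogen, not the aromatic carbon of the five-membered ring, so it does not bear on the present change.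

Compound 4 `CCn1c(NC(C)C)nc2c(-c3ccnc(OC)c3)csc2c1=O` differs from compound 2 by 2-methoxypyridin-4-yl in place of pyridin-3-yl on an aromatic carbon. Among the compounds with values here, no measured pair covers such a change, so the step of a 1.2-fold lower number from compound 2 to compound 4 (0.06 log units; within the scatter) is expected to stay within the scatter, with compound 2 itself as the anchor. Compound 4 is therefore estimated at 5 ug/mL in this assay, within 1.5 ug/mL to 15 ug/mL.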

Compound 4, solubility: 2.4 ug/mL
Compound 4: middle estimate off by 2.1-fold (0.32 log units), on the high side; low and high end bracket the measured number.
By their numbers in this assay, from the lowest: compound 4; then compound 2; then compound 1; then compound 3.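

In this assay, the aromatic carbon two ring bonds from the ring sulfur responds to a change of aryl group: 2-methoxypyridin-4-yl in place of pyridin-3-yl gives a 2.4-fold lower number from compound 2 to compound 4 (0.38 log units; beyond the scatter), a modest step beyond the scatter. Going by these compounds alone, this is the first step read at this position, as the earlier step concerned only the group on the ring nitrogen. Nothing available accounts for this step.

The step joins two changes, the added methoxy and the different attachment point of the pyridine, and the compounds shown do not separate them. Going by these compounds, how a carboxylic acid or a dimethylamino group on this aromatic carbon would read also remains open.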